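Swapping an alkoxy arm for a dimethoxyphenyl ring

The compounds below may be only part of what the source reports. "The series", "measured", "known", "first", "only" and "open" are said of these compounds alone.

Compound 1, `COc1ccc(N2CCN(c3cc(C(F)(F)F)ccc3CNC(=O)C(C)c3ccc(NS(C)(=O)=O)c(F)c3)CC2)cc1`, gives 1.6 nM in an assay on CHO cells for antagonist activity at transient receptor potential cation channel subfamily V member 1 (Homo sapiens), read by FLIPR; on this read-out higher numbers stand for weaker inhibition and lower numbers for stronger inhibition.
Compound 2, `CCCCCCOc1cc(C(C)(F)F)ccc1CNC(=O)C(C)c1ccc(NS(C)(=O)=O)c(F)c1`, gives 0.8 nM in this assay.
Compound 3, `CC(C)COc1cc(C(F)(F)F)ccc1CNC(=O)C(C)c1ccc(NS(C)(=O)=O)c(F)c1`, gives 0.8 nM in this assay.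

All three measured compounds share the same amide core and differ only in the group carried by the benzylic aromatic ring. On the numbers in hand compound 3 stands level with compound 2 at the digits shown, the two together giving the lowest values of the set, and its gap to compound 1 also lies within the usual scatter, so no order among the three can be claimed.

Compound 4, `COc1ccc(-c2cc(C(F)(F)F)ccc2CNC(=O)C(C)c2ccc(NS(C)(=O)=O)c(F)c2)cc1OC`, has not yet been measured. It differs from compound 3 in one place, (3,4-dimethoxyphenyl in place of isobutoxy on an aromatic carbon), so a ring replaces a branched chain on an aromatic carbon that is ortho to a large group and meta to a trifluoromethyl group. Compound 1 carries an even larger aryl-bearing group at the same position and still gives 1.6 nM, so the set gives no reason to expect a large loss.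

Compound 4 is therefore expected to give about 1.5 nM, most likely between 0.4 nM and 6 nM, which corresponds to an estimated step of a 1.9-fold higher number from compound 3 to compound 4 (0.27 log units; within the scatter), a small shift toward a higher number that is expected to stay close to the scatter.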

Compound 4, inhibition constant: 8.6 nM
Compound 4: the middle estimate sits 5.7-fold (0.76 log units) below what was measured; measured number above the stated range.
By their numbers in this assay, from the lowest: compounds 2, 3 and 1 (each within the scatter of the next); then compound 4.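

In this assay, among the compounds shown here, placing 3,4-dimethoxyphenyl in place of isobutoxy on the aromatic carbon that is ortho to a large group and meta to a trifluoromethyl group gives an 11-fold higher number from compound 3 to compound 4 (1.03 log units; beyond the scatter), the only step in the set that lies beyond the scatter, so this carbon does not take every substituent alike. The presence of a ring in the group at this carbon does not settle the outcome by itself: compound 1, whose group there also carries an aromatic ring, gives 1.6 nM in this assay, while compound 4 gives 8.6 nM. Nothing measured here accounts for the step, so its cause remains unexplained.

The compounds shown leave open whether the higher number goes with an aromatic ring joined directly to this carbon, with the loss of the oxygen link, or with the two methoxy groups on the entering ring. A plain phenyl ring, a 4-methoxyphenyl ring or a benzyloxy group at the same carbon would begin to separate these possibilities.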